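Two Furoyl Thioimidazolidines Measured, a Benzoyl Analogue Expected

The compounds below may be only part of what the source reports. "The series", "measured", "known", "first", "only" and "open" are said of these compounds alone.

Compound 1 `N#C/C(=C\N1CCN(C(=O)c2ccco2)C1=S)C(=O)Nc1ccc(Cl)cc1` and compound 2 `N#C/C(=C\N1CCN(C(=O)c2ccco2)C1=S)C(N)=O` share a core built around a furan carbonyl and a thioimidazolidine ring, with a nitrile-bearing side chain. In a functional assay on SNB-19 cells (Homo sapiens) for inhibition, read by sulforhodamine B assay, with a stated time of 48 h (a higher number here means a weaker inhibitor of growth, a lower number a stronger inhibitor of growth), compound 1 gives 27600 nM, and compound 2 gives 36400 nM. Of these two numbers, compound 2 is the one farther from zero, but the step of a 1.3-fold higher number from compound 1 to compound 2 (0.12 log units; within the scatter) lies within the scatter, so the two compounds cannot be told apart on this evidence.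

Compound 3 `N#C/C(=C\N1CCN(C(=O)c2ccco2)C1=S)C(=O)c1ccccc1` has not yet been measured. It differs from compound 2 by phenyl in place of amino on a carbonyl carbon. Among the compounds with values here, only one measured step exists here, the step from compound 1 to compound 2, in which a 4-chlorophenyl on an amide-type nitrogen was replaced by hydrogen with a 1.3-fold higher number from compound 1 to compound 2 (0.12 log units; within the scatter); an aromatic group at this end of the molecule therefore made no difference beyond the scatter. On that basis the expected step of a 1.2-fold lower number from compound 2 to compound 3 (0.08 log units; within the scatter) is small, with no clear direction. In this assay compound 3 is expected to give 30000 nM, within a range from 10000 nM to 90000 nM.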

Compound 3, concentration for 50% growth inhibition: 39700 nM
Beside the measured number, compound 3's estimate is 1.3-fold (0.12 log units) below it; the measured number falls inside the stated range.
By their numbers in this assay, from the lowest: compounds 1, 2 and 3 (each within the scatter of the next).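

In this assay, the earlier pair changed only what sits on the amide-type nitrogen, whereas this result removes that nitrogen and its hydrogen-bond donor from the carbonyl carbon, and a 1.1-fold higher number from compound 2 to compound 3 (0.04 log units; within the scatter) still leaves the two compounds indistinguishable. Putting phenyl in place of (4-chlorophenyl)amino on the same carbon gives a 1.4-fold higher number from compound 1 to compound 3 (0.16 log units; within the scatter), so amino, (4-chlorophenyl)amino and phenyl on a carbonyl carbon joined to the double-bonded chain carbon cannot be told apart in this assay, whether or not a nitrogen links the group to that carbon. No supporting evidence is available to explain why these three groups read alike.

As far as these compounds go, all three compounds keep the same furan carbonyl and thioimidazolidine portion, so it remains open whether the shared core, rather than this end of the molecule, is where the numbers could be moved. From the compounds shown here alone, it also remains open whether a quite different group on this carbonyl carbon, such as a hydroxyl giving a carboxylic acid or a longer alkyl chain, would produce a step beyond the scatter.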